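This account rests on a few compounds, and the source may have more. Where it says the series, first, only, none or still open, it means among the compounds named here.

In a functional assay on HT-29 cells (Homo sapiens) for inhibition, read by sulforhodamine B assay, with a stated time of 72 h (on this read-out lower numbers stand for stronger inhibition and higher numbers for weaker inhibition), compound 1 `COc1cc(N2C(=O)CC2c2ccc(SC)cc2)cc(OC)c1OC` gives 108 nM and compound 2 `COc1ccc(C2C(C3CC3)C(=O)N2c2cc(OC)c(OC)c(OC)c2)cc1` gives 107 nM, while compound 3 `C=CC1C(=O)N(c2cc(OC)c(OC)c(OC)c2)C1c1ccc(OC)cc1` gives 10 nM as the lowest number of the three. The change to compound 4 `COc1ccc(C2CC(=O)N2c2cc(OC)c(OC)c(OC)c2)cc1` is hydrogen in place of vinyl on a saturated ring carbon and nothing else differs. Within the data shown here, only one measured step touches that carbon, and it is large: it shows an 11-fold lower number from compound 2 to compound 3 (1.03 log units; beyond the scatter) with vinyl in place of cyclopropyl. Compound 1 also has hydrogen at that carbon but differs elsewhere, and compound 1 sits at 108 nM here. An estimated step of an 11-fold higher number from compound 3 to compound 4 (1.04 log units; beyond the scatter) is therefore expected in this assay with the number going up, beyond the scatter. The expected value for compound 4 is 110 nM (estimated range 35 nM to 350 nM).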

Compound 4, half-maximal inhibitory concentration: 65 nM
Estimate against measurement, compound 4: 1.7-fold (0.23 log units) above; the measured number falls inside the stated range.
By their numbers in this assay, from the lowest: compound 3; then compounds 4, 2 and 1 (each within the scatter of the next).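

In this assay, hydrogen in place of vinyl gives a 6.5-fold higher number from compound 3 to compound 4 (0.81 log units; beyond the scatter) on this saturated ring carbon, so vinyl stands apart from hydrogen as well as from cyclopropyl. Hydrogen and cyclopropyl cannot be told apart at this carbon, since a 1.6-fold lower number from compound 2 to compound 4 (0.22 log units; within the scatter) is a step inside the usual scatter. Methoxy and methylsulfanyl on the aromatic carbon also cannot be told apart, since a 1.7-fold lower number from compound 1 to compound 4 (0.22 log units; within the scatter) is likewise inside the scatter.

Going by these compounds, whether an ethyl group or an amine on the saturated ring carbon would match vinyl remains open. No measurement here explains what sets vinyl apart.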